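The compounds below may be only part of what the source reports. "The series", "measured", "known", "first", "only" and "open" are said of these compounds alone.

Measured compounds:

- compound 1 `COc1cc(-c2cc(/C=C/C(=O)c3ccc(N)cc3)[nH]n2)cc(OC)c1OC` — 2000 nM
- compound 2 `COc1ccc2c(c1)C/C(=C\c1cc(-c3cc(OC)c(OC)c(OC)c3)n[nH]1)C2=O` — 2000 nM

In a functional assay on MDA-MB-231 cells (Homo sapiens) for inhibition, read by MTT assay, with a stated time of 48 h (on this read-out higher numbers stand for weaker inhibition and lower numbers for stronger inhibition), compound 1 gives 2000 nM. Compound 2, which carries the same trimethoxyphenyl-pyrazole part on a different core, gives 2000 nM in this assay. The two values are level at the digits shown and differ by nothing beyond the scatter, so no order between compound 1 and compound 2 can be read from them.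

Compound 3 `COc1cc2c(cc1OC)C(=O)/C(=C/c1cc(-c3cc(OC)c(OC)c(OC)c3)n[nH]1)C2` has not yet been measured in this assay. It differs from compound 2 in one place: methoxy in place of hydrogen on an aromatic carbon. Going by the values given here, no step between two measured compounds covers this change, so there is no precedent from which to set its size or direction. On the two values at hand, which show the same level of inhibition across a change of core, the working expectation is a step of no change at the digits printed from compound 2 to compound 3 (within the scatter) that stays within the scatter, in no particular direction. Compound 3 is accordingly expected to give about 2000 nM in this assay, with a range from 800 nM to 5000 nM.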

Compound 3, half-maximal inhibitory concentration: 2500 nM
Compound 3: the middle estimate sits 1.3-fold (0.10 log units) below what was measured; low and high end bracket the measured number.
By their numbers in this assay, from the lowest: compounds 1, 2 and 3 (each within the scatter of the next).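

In this assay, going by these compounds alone, methoxy in place of hydrogen on an aromatic carbon gives a 1.3-fold higher number from compound 2 to compound 3 (0.10 log units; within the scatter), the first step that isolates a single place, since compound 1 and compound 2 differ in their core. At this place, on the six-membered aromatic ring of carbon only that is part of the fused system and ortho to a methoxy group, the added methoxy leaves compound 3 at a level that cannot be told apart from that of compound 2. No supporting evidence on this result is at hand, and the step itself gives no reason for it.

A single substituent at this place says little about how far the level would hold with a hydroxyl group, an amine, a halogen such as chlorine or a longer alkoxy chain such as ethoxy in its stead. From the compounds shown here alone, it also remains open whether a methoxy group on this ring counts at all when the methoxy group ortho to this place is replaced by hydrogen.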